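Anilino variation on a shared diaryl ether core

A few compounds are considered here, and "the series" means these few. Any claim that something is new, unique, unknown or untested is made for them only; others in the source may bear on it.

Three compounds share one core and differ only in the aryl group on the anilino nitrogen. Compound 1 `CNC(=O)c1ccccc1Oc1nc(Nc2ccc(Br)cc2)ncc1Br` carries a 4-bromophenyl there; in a functional assay on A549 cells (Homo sapiens) for antiproliferative activity, read by MTT assay, with a stated time of 24 h (a lower number here means a stronger inhibitor, a higher number a weaker inhibitor), compound 1 gives 23500 nM. Compound 2 `CNC(=O)c1ccccc1Oc1nc(Nc2ccccc2F)ncc1Br` carries a 2-fluorophenyl, and in this assay compound 2 gives 35500 nM. Compound 3 `CNC(=O)c1ccccc1Oc1nc(Nc2ccccc2OC)ncc1Br` carries a 2-methoxyphenyl, and in this assay compound 3 gives 40500 nM. Compound 1 sits at one end of these three numbers, yet compound 2 and compound 3 are each within the scatter of it: the step of a 1.5-fold higher number from compound 1 to compound 2 (0.18 log units; within the scatter), the step of a 1.7-fold higher number from compound 1 to compound 3 (0.24 log units; within the scatter) and the step of a 1.1-fold higher number from compound 2 to compound 3 (0.06 log units; within the scatter) are all small.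

Compound 4 `CNC(=O)c1ccccc1Oc1nc(Nc2cccc(OC)c2)ncc1Br` differs from compound 1 by 3-methoxyphenyl in place of 4-bromophenyl on a nitrogen on an aromatic ring. The two steps that bear on this, from compound 1 to compound 2 and from compound 1 to compound 3, show that exchanging the aryl group on this nitrogen has so far moved this assay no further than the scatter. No step beyond the scatter is therefore expected here either. For compound 4 the expected step is a 1.3-fold higher number from compound 1 to compound 4 (0.11 log units; within the scatter), and the number expected in this assay is 30000 nM, ranging from 12000 nM to 75000 nM.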

Compound 4, half-maximal inhibitory concentration: 6230 nM
Estimate against measurement, compound 4: 4.8-fold (0.68 log units) above, and the stated range ends above it.
By their numbers in this assay, from the lowest: compound 4; then compounds 1, 2 and 3 (each within the scatter of the next).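

In this assay, within the data shown here, the aryl group on this nitrogen can move the number after all: a 3.8-fold lower number from compound 1 to compound 4 (0.58 log units; beyond the scatter) is the first step beyond the scatter. The placement of the methoxy group also counts, since 3-methoxyphenyl and 2-methoxyphenyl carry the same group and the step of a 6.5-fold lower number from compound 3 to compound 4 (0.81 log units; beyond the scatter) is the largest so far, while the step of a 5.7-fold lower number from compound 2 to compound 4 (0.76 log units; beyond the scatter) points the same way. Nothing shown gives a reason for the lower number of compound 4.

Open, as far as these compounds go, is whether this lower number is tied to the methoxy group itself or would also appear with 3-chlorophenyl, 3-hydroxyphenyl or 3-aminophenyl on this nitrogen. Also open, from the compounds shown here alone, is where 4-methoxyphenyl would fall, as it would complete the methoxy set and allow a direct comparison with the 4-bromophenyl of compound 1.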